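From methylamino to benzylamino: a step into the unknown

The source may report more compounds than this note shows. Statements on the series, on what has been measured and on what is new or still open speak of the compounds shown alone.

Of the compounds shown here, three have so far been tested in a functional assay on MV4-11 cells (Homo sapiens) for antiproliferative activity, read by CellTiter-Glo, with a stated time of 72 h (a higher number here means a weaker inhibitor of growth, a lower number a stronger inhibitor of growth), and only two of them gave a number. Compound 1 `CC(C)(C)OC(=O)Nc1nc(-c2cc(F)ncc2Cl)cs1` returns > 10000 nM which is a limit of the assay and not a number. Compound 2 `COC[C@H](C)N[C@H]1CC[C@H](Nc2cc(-c3csc(NCC4CCOCC4)n3)c(Cl)cn2)CC1` gives 440 nM and compound 3 `CNc1nc(-c2cc(N[C@H]3CC[C@H](NCCOC)CC3)ncc2Cl)cs1` gives 530 nM so these two lie within the scatter of each other and cannot be ranked.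

Compound 4 `COCCN[C@H]1CC[C@H](Nc2cc(-c3csc(NCc4ccccc4)n3)c(Cl)cn2)CC1` has not yet been measured. Its difference from compound 3 is phenyl in place of hydrogen on a saturated chain carbon bound to a nitrogen on an aromatic ring and in words this is phenyl in place of hydrogen on a saturated chain carbon bound to a nitrogen on an aromatic ring, which turns methylamino into benzylamino.

Among the compounds with values here, no measured pair shows this change, so the forecast is uncertain. Starting from compound 3 at 530 nM only a small shift toward a lower number is expected in this assay and it may not exceed the scatter. The estimated step is a 1.5-fold lower number from compound 3 to compound 4 (0.18 log units; within the scatter) on this reasoning. Compound 4 is estimated at 350 nM with an expected range from 100 nM to 1200 nM around it.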

Compound 4, concentration for 50% growth inhibition: 330 nM
Compound 4: middle estimate off by 1.1-fold (0.03 log units), on the high side, and the stated range covers the measured number.
By their numbers in this assay, from the lowest: compounds 4, 2 and 3 (each within the scatter of the next). At a limit, above all of these: compound 1.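

In this assay the change from methylamino to benzylamino gives a 1.6-fold lower number from compound 3 to compound 4 (0.21 log units; within the scatter) and so shows that this place on the shared core can take a phenyl, with its six carbon atoms, while the growth inhibition stays in the same range. Within the data shown here, this is the first pair of measured compounds that differ in one place only, so the series now has one direct reading of a single change, though it covers only this one group. Nothing measured here gives a reason for this outcome.

On these data alone, a longer chain such as phenethylamino, or a benzylamino group carrying an amine or a carboxylic acid on its phenyl, remains open at this place. Among these compounds, the one step that can be read lies within the scatter, and whether any group here gives a step beyond it also remains open.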